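Acetyl to pentyloxycarbonyl on the shared core

The compounds below may be only part of what the source reports. "The series", "measured", "known", "first", "only" and "open" are said of these compounds alone.

Measured compounds:
Compound 1 `CC(=O)OC[C@H]1O[C@@H](n2cnc3c(N)ncnc32)[C@H](O)[C@@H]1O` gives > 100000 nM in an assay on COS-7 cells for inhibition of sodium/nucleoside cotransporter 2 (Homo sapiens), read by scintillation counting, in the presence of a further agent that is not named here (on this read-out higher numbers stand for weaker inhibition and lower numbers for stronger inhibition), which is a limit of the assay and not a number.
Compound 2 `Nc1ncnc2c1nc(NCc1cccc(Cl)c1)n2[C@@H]1O[C@H](CO)[C@@H](O)[C@H]1O` gives 5400 nM in this assay.
Compound 3 `COc1ccccc1CNc1nc2c(N)ncnc2n1[C@@H]1O[C@H](CO)[C@@H](O)[C@H]1O` gives > 100000 nM in this assay, again a limit and not a number.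

Compound 1 thus stands at the limit of > 100000 nM in this assay, at which 2 of the 3 values shown sit, the place where compound 3 also sits, while compound 2 alone gives a measured number. Among the measured compounds shown here, the single measured step, an at least 18-fold higher number from compound 2 to compound 3 (1.26 log units; beyond the scatter), concerns the group on the saturated chain carbon bound to a nitrogen on an aromatic ring and leaves the carbonyl carbon untouched, so no measured step bears directly on the change examined here.

Compound 4 `CCCCCOC(=O)OC[C@H]1O[C@@H](n2cnc3c(N)ncnc32)[C@H](O)[C@@H]1O` differs from compound 1 by pentyloxy in place of methyl on a carbonyl carbon. For the measured compounds named here, with compound 1 known only as a limit and no comparable step measured, the step of a number no higher from compound 1 to compound 4 (the limit leaves the size open) is expected to be small or not resolvable. Compound 4 is therefore estimated at 100000 nM, within 20000 nM to 300000 nM, and a further limit rather than a number is the likelier outcome.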

Compound 4, half-maximal inhibitory concentration: > 100000 nM
Compound 4: a limit, no number; the forecaster's own chance of this, stated with the estimate: 70%; the middle value sits exactly at the limit.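

In this assay compound 4, like compound 1, gives a limit and not a number, so no step between compound 1 and compound 4 can be read: the limit of > 100000 nM in this assay, at which 3 of the 4 values shown sit.

The compounds shown leave open whether pentyloxy in place of methyl on a carbonyl carbon changes inhibition at all.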